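A few compounds are considered here, and "the series" means these few. Any claim that something is new, unique, unknown or untested is made for them only; others in the source may bear on it.

In a physicochemical assay for metabolic stability, read by HPLC (on this read-out lower numbers stand for a shorter-lived compound and higher numbers for a longer-lived compound), compound 1 `Cc1cn([C@H]2C[C@H](N=[N+]=[N-])[C@@H](COP(=O)(O)Oc3cncc(Cl)c3)O2)c(=O)[nH]c1=O` gives 7.27 h and compound 2 `Cc1ncccc1OP(=O)(O)OC[C@H]1O[C@@H](n2cc(C)c(=O)[nH]c2=O)C[C@@H]1N=[N+]=[N-]` gives 15.8 h as the higher of the two numbers. Compound 3 `Cc1cn([C@H]2C[C@H](N=[N+]=[N-])[C@@H](COP(=O)(O)Oc3cccnc3Cl)O2)c(=O)[nH]c1=O` differs from compound 2 in one place (chloro in place of methyl on an aromatic carbon), with chloro in place of methyl on an aromatic carbon, so that 2-methylpyridin-3-yl becomes 2-chloropyridin-3-yl. Going by the values given here, one measured step bears on this change (a 2.2-fold higher number from compound 1 to compound 2 (0.34 log units; beyond the scatter)), and it is modest but beyond the scatter. That step put 2-methylpyridin-3-yl in place of 5-chloropyridin-3-yl, which is roughly the reverse swap, although the chloro of compound 3 lies next to the ring nitrogen and so the guide is imperfect. A lower number of similar modest size is therefore expected in this assay, and the estimated step (a 2.3-fold lower number from compound 2 to compound 3 (0.35 log units; beyond the scatter)) carries real uncertainty. For compound 3 the estimate is 7 h with an expected range from 3 h to 15 h in repeated measurements.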

Compound 3, half-life: 16.3 h
The estimate for compound 3 lay 2.3-fold (0.37 log units) below the measured number; measured number outside the range, above it.
By their numbers in this assay, from the lowest: compound 1; then compounds 2 and 3 (each within the scatter of the next).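

In this assay, chloro and methyl on the aromatic carbon next to the ring nitrogen cannot be told apart, with a 1.0-fold higher number from compound 2 to compound 3 (0.01 log units; within the scatter), so at this position the two groups serve equally well on this read-out. Where the chloro sits does matter: a 2.2-fold higher number from compound 1 to compound 3 (0.35 log units; beyond the scatter), a modest step beyond the scatter that comes from the change of 5-chloropyridin-3-yl to 2-chloropyridin-3-yl. The shown data offer no measurement that explains either result.

From the compounds shown here alone, whether this position accepts other groups equally well remains open, since a methoxy, an amine or a plain hydrogen there could give a quite different half-life. Whether a methyl at the place held by the chloro in compound 1 would match that compound also remains unanswered.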